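This account rests on a few compounds, and the source may have more. Where it says the series, first, only, none or still open, it means among the compounds named here.

Values so far in a functional assay on MV4-11 cells (Homo sapiens) for antiproliferative activity, read by CCK-8 assay, with a stated time of 72 h; on this read-out lower numbers stand for stronger inhibition and higher numbers for weaker inhibition:
- compound 1 `CC(C)Oc1ccccc1-c1cn(C)c(=O)c2[nH]c(C(=O)NCc3ccc(C(=O)Nc4ccccc4N)cc3)cc12` gives 130 nM
- compound 2 `COc1ccc(C(C)(C)O)cc1-c1cn(C)c(=O)c2[nH]c(C(=O)NCc3ccc(C(=O)Nc4ccccc4N)cc3)cc12` gives 420 nM
- compound 3 `Cn1cc(-c2cccc(F)c2)c2cc(C(=O)NCc3ccc(C(=O)Nc4ccccc4N)cc3)[nH]c2c1=O` gives 210 nM

Compound 3 cannot be separated from either of the other two: a 1.6-fold higher number from compound 1 to compound 3 (0.21 log units; within the scatter) and a 2.0-fold lower number from compound 2 to compound 3 (0.30 log units; within the scatter) are the steps that place it. Compound 4 `Cn1cc(-c2cccc(Cl)c2)c2cc(C(=O)NCc3ccc(C(=O)Nc4ccccc4N)cc3)[nH]c2c1=O` makes one small change to compound 3: chloro in place of fluoro on an aromatic carbon with chloro in place of fluoro on an aromatic carbon. Among the measured compounds shown here, no measured step tests this swap directly. For the measured compounds named here, exchanging the whole substituted phenyl group gave at most a modest shift, a 3.2-fold higher number from compound 1 to compound 2 (0.51 log units; beyond the scatter) being the only step beyond the scatter. So in this assay no step beyond the scatter is expected, and the estimated step is a 1.1-fold lower number from compound 3 to compound 4 (0.02 log units; within the scatter) in size. Compound 4 is expected at 200 nM with an estimated range of 100 nM to 400 nM in this read-out.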

Compound 4, half-maximal inhibitory concentration: 190 nM
Compound 4: middle estimate off by 1.1-fold (0.02 log units), on the high side; low and high end bracket the measured number.
By their numbers in this assay, from the lowest: compounds 1, 4, 3 and 2 (each within the scatter of the next, the first and the last beyond it).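

In this assay chloro in place of fluoro, meta to a large group, gives a step too small to separate the two compounds (a 1.1-fold lower number from compound 3 to compound 4 (0.04 log units; within the scatter)). The 3-chlorophenyl compound also cannot be separated from the 2-isopropoxyphenyl compound (a 1.5-fold higher number from compound 1 to compound 4 (0.16 log units; within the scatter)), but it does separate modestly from the 5-(1-hydroxy-1-methylethyl)-2-methoxyphenyl compound (a 2.2-fold lower number from compound 2 to compound 4 (0.34 log units; beyond the scatter)), which the 3-fluorophenyl compound did not. No evidence here bears on the reason for these numbers. Only two halogens are shown at this place, so what an amine or a carboxylic acid would do there remains open.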